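Swapping an Amide Side Chain in an L02 Cytotoxicity Series

This account rests on a few compounds, and the source may have more. Where it says the series, first, only, none or still open, it means among the compounds named here.

Of the compounds shown here, two have been measured so far. In an ADME assay on L02 cells (Homo sapiens) for cytotoxicity, read by MTT assay, with a stated time of 48 h (a higher number here means a weaker inhibitor, a lower number a stronger inhibitor), compound 1 (`CCn1c(C(=O)NCCCN(C)C)ccc1C(CC)(CC)c1ccc(OCC(=O)C(C)(C)C)c(C)c1`) gives 670 nM and compound 2 (`CCn1c(C(=O)NCC(OC)OC)ccc1C(CC)(CC)c1ccc(OCC(O)C(C)(C)C)c(C)c1`) gives 22200 nM as the higher of the two numbers. The gap between them lies beyond the usual scatter, so compound 2 is the weaker inhibitor of this pair.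

The next compound is compound 3 (`CC[C@@H](C)[C@H](NC(=O)c1ccc(C(CC)(CC)c2ccc(OCC(O)C(C)(C)C)c(C)c2)n1CC)C(=O)O`), which shares the core of compound 2 and differs from it in one place. The difference is 1-carboxy-2-methylbutyl in place of 2,2-dimethoxyethyl on an amide-type nitrogen and amounts to 1-carboxy-2-methylbutyl in place of 2,2-dimethoxyethyl on an amide-type nitrogen.

Within the data shown here, no measured pair shows this change or any other single change, so the data offer no step to carry over. The expectation therefore starts from compound 2 at 22200 nM and allows only a modest move toward a higher number in this assay with no step beyond the scatter expected. The expected change is an estimated 1.6-fold higher number from compound 2 to compound 3 (0.20 log units; within the scatter) and remains uncertain. For compound 3 the estimated value is 35000 nM with an expected range from 11000 nM to 100000 nM in this measurement.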

Compound 3, half-maximal inhibitory concentration: 1400 nM
Estimate against measurement, compound 3: 25-fold (1.40 log units) above; the measured number lies below the stated range.
By their numbers in this assay, from the lowest: compound 1; then compound 3; then compound 2.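

Among these compounds, this step is the first single change that can be read, and it shows that the group on the amide-type nitrogen matters in this assay: with the rest of compound 2 held fixed, 1-carboxy-2-methylbutyl in place of 2,2-dimethoxyethyl gives a 16-fold lower number from compound 2 to compound 3 (1.20 log units; beyond the scatter), a large move beyond the scatter. The exchange alters several things at once, since the entering group brings a carboxyl function with a hydrogen-bond donor, a longer carbon skeleton and two defined stereocentres, so this single pair cannot assign the step to any one of them. Nothing in the available evidence accounts for the size or direction of this step.

The compounds shown leave open whether the carboxylic acid itself matters or whether the branched carbon chain would give a similar number without it, a question that a methyl ester of the same acid or a shorter chain ending in a carboxylic acid would address. They also leave open whether the step depends on the stereocentres of the entering group, and whether it would recur on a core carrying a different group elsewhere.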